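Trading an Isopropyl for a Methoxycarbonyl on the Aryl Ring

The source may report more compounds than this note shows. Statements on the series, on what has been measured and on what is new or still open speak of the compounds shown alone.

Measured compounds:
- compound 1 `CC(C)c1ccc(N2C(=O)C=CC2OCC(F)(F)F)cc1`: 6620 nM
- compound 2 `O=C1C=CC(OCC(F)(F)F)N1c1cc(F)cc(F)c1`: 520 nM
- compound 3 `O=C1C=CC(OCC(F)(F)F)N1c1ccccc1F`: 12000 nM

Of the compounds shown here, three sharing one core have been tested in a functional assay on K562 cells (Homo sapiens) for inhibition (on this read-out higher numbers stand for weaker inhibition and lower numbers for stronger inhibition), and they differ only in the aromatic ring attached to the core. Compound 1 stands second highest of the three numbers, with 6620 nM in this assay. Its nearest neighbour is compound 3, whose number of 12000 nM lies within the usual scatter of compound 1, so the two cannot be told apart. Compound 2 is the clear outlier, giving 520 nM, well beyond the scatter and the lowest number of the set.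

The next compound, compound 4 `COC(=O)c1ccc(N2C(=O)C=CC2OCC(F)(F)F)cc1`, has not yet been measured. It differs from compound 1 in one place: methoxycarbonyl in place of isopropyl on an aromatic carbon. No comparable change has been measured among these three compounds, so there is no basis for expecting a shift beyond the scatter in either direction in this assay.

The step from compound 1 to compound 4 is therefore expected to be small, a 1.1-fold higher number from compound 1 to compound 4 (0.05 log units; within the scatter). Compound 4 is estimated at 7500 nM, within a range of 2000 nM to 25000 nM.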

Compound 4, half-maximal inhibitory concentration: 14700 nM
Beside the measured number, compound 4's estimate is 2.0-fold (0.29 log units) below it; measured number inside the range.
By their numbers in this assay, from the lowest: compound 2; then compounds 1, 3 and 4 (each within the scatter of the next, the first and the last beyond it).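

Among the compounds shown here, this pair gives the first direct look at what a single change does at this position, the aromatic carbon para to a large group. In this assay, methoxycarbonyl in place of isopropyl gives a 2.2-fold higher number from compound 1 to compound 4 (0.35 log units; beyond the scatter), so inhibition becomes weaker and the position is shown to respond to what sits on it, though only modestly. The exchange puts a group carrying hydrogen-bond acceptors and a double bond where a group with neither stood, but nothing available here explains why the number moved.

As far as these compounds go, a single pair cannot separate the parts of this change, so it remains open whether the acceptors, the double bond or simply the different shape of the group goes with the higher number. Also open, from the compounds shown here alone, is how other groups on this same carbon would read in this assay, such as a carboxylic acid, an amine, a nitrile or a longer alkyl chain, and whether any of them would move the number down rather than up.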